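Halogen swap on the aryl amide of the shared core

The source may report more compounds than this note shows. Statements on the series, on what has been measured and on what is new or still open speak of the compounds shown alone.

Measured so far:
compound 1 `CN(Cc1ccc(Br)cc1OC(F)(F)F)CC1CCC(CNc2nc(N(C)C)c3ccccc3n2)CC1` gives 5600 nM in an assay on HEK293 cells for inhibition of melanin-concentrating hormone receptor 1 (Homo sapiens), read by radioligand binding; on this read-out higher numbers stand for weaker inhibition and lower numbers for stronger inhibition
compound 2 `CN(C)c1nc(N[C@H]2CC[C@@H](NC(=O)c3cccc(F)c3)CC2)nc2ccccc12` gives 9.5 nM in this assay
compound 3 `Cc1cccc(C(=O)N[C@H]2CC[C@@H](Nc3nc(N(C)C)c4ccccc4n3)CC2)c1` gives 4.6 nM in this assay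

Compound 2 stands second highest of the three numbers in this assay; its nearest neighbour is compound 3, with a 2.1-fold lower number from compound 2 to compound 3 (0.31 log units; beyond the scatter), and compound 1 lies far off with a much higher number. Compound 4 `CN(C)c1nc(N[C@H]2CC[C@@H](NC(=O)c3cccc(Cl)c3)CC2)nc2ccccc12` differs from compound 2 by chloro in place of fluoro on an aromatic carbon. Among the measured compounds shown here, the only measured step at this place is a 2.1-fold lower number from compound 2 to compound 3 (0.31 log units; beyond the scatter), methyl in place of fluoro; no step with chloro itself has been measured. A step of comparable size toward a lower number is therefore expected, a 1.6-fold lower number from compound 2 to compound 4 (0.20 log units; within the scatter). In this assay compound 4 is estimated to give 6 nM, with a range from 3 nM to 15 nM.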

Compound 4, half-maximal inhibitory concentration: 4.5 nM
Compound 4: the middle estimate sits 1.3-fold (0.12 log units) above what was measured, within the range that was stated.
By their numbers in this assay, from the lowest: compounds 4 and 3 (each within the scatter of the next); then compound 2; then compound 1.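

In this assay, chloro at this aromatic carbon reads like methyl rather than fluoro: there is a 2.1-fold lower number from compound 2 to compound 4 (0.32 log units; beyond the scatter) and then a 1.0-fold lower number from compound 3 to compound 4 (0.01 log units; within the scatter), so compound 3 and compound 4 cannot be told apart. Two different replacements of fluoro now give a modest step in the same direction, though the series holds only these three groups at this carbon. Nothing measured here accounts for chloro and methyl reading alike. Open, going by these compounds, is whether methoxy, trifluoromethyl or nitrile at the same carbon would hold this level, and whether an amine or a carboxylic acid there would.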